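The compounds below may be only part of what the source reports. "The series", "measured", "known", "first", "only" and "open" are said of these compounds alone.

Compound 1 `O=c1cc(-c2cccc(Cl)c2)oc2ccccc12` is a flavone bearing a chloro group on its pendant phenyl ring, and compound 2 `COc1ccccc1-c1cc(=O)c2ccccc2o1` carries a methoxy group at a different place on the same kind of core. For the measured compounds named here, in an ADME assay on MDCK cells (Canis lupus familiaris) for cytotoxicity, read by MTT assay (a lower number here means that less compound is tolerated, a higher number that more compound is tolerated), compound 1 gives 174000 nM, while compound 2 gives 171000 nM; these two numbers sit within the scatter of each other, so neither can be told apart from the other, and compound 1 stands level with the only other measured compound. The next compound, compound 3 `O=c1cc(-c2cccc([N+](=O)[O-])c2)oc2ccccc12`, differs from compound 1 in a single spot: nitro in place of chloro on an aromatic carbon. Going by the values given here, no measured pair shows what such a swap does here, so the expectation rests on the two numbers alone. The step from compound 1 to compound 3 in this assay is expected to be small, a 1.1-fold lower number from compound 1 to compound 3 (0.04 log units; within the scatter), with no clear direction beyond the scatter. Compound 3 is therefore estimated at 160000 nM, within a range of 80000 nM to 320000 nM.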

Compound 3, half-maximal cytotoxic concentration: 269000 nM
Beside the measured number, compound 3's estimate is 1.7-fold (0.23 log units) below it, and the stated range covers the measured number.
By their numbers in this assay, from the lowest: compounds 2, 1 and 3 (each within the scatter of the next).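

In this assay, nitro in place of chloro on this aromatic carbon gives a 1.5-fold higher number from compound 1 to compound 3 (0.19 log units; within the scatter), so this first measured swap at this position cannot be told apart from no change. Three heavy atoms, including two hydrogen-bond acceptors, enter where a single chlorine leaves, yet this larger group brings no step beyond the scatter, which holds for these two groups only. No measured evidence bears on this result.

As far as these compounds go, whether an amine or a carboxylic acid on this same aromatic carbon would also stay within the scatter remains open. So does whether any change elsewhere on the shared core would produce a clear step, since compound 2 differs from compound 1 in more than one place and gives no reading of a single change.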